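Distal aryl exchange and acid dissociation in one series

The source may report more compounds than this note shows. Statements on the series, on what has been measured and on what is new or still open speak of the compounds shown alone.

Measured so far:
compound 1 `COc1cccc(CNCCCNc2ccnc3cc(CCC(C)C)ccc23)c1O` gives 9.47
compound 2 `COc1cccc(CNCCCNc2ccnc3cc(Cc4ccc(C#N)cc4)ccc23)c1O` gives 9.47
compound 3 `COc1cccc(CNCCCNc2ccnc3cc(-c4cccc5ccccc45)ccc23)c1O` gives 9.47

In a physicochemical assay for acid dissociation, compound 3 gives 9.47 and sits level with compounds 1 and 2 at the digits shown; the gap to compound 1 and the gap to compound 2 both lie within the scatter. The three measured steps each change only the group on the far side of the shared core: no change at the digits printed from compound 1 to compound 2 (within the scatter), no change at the digits printed from compound 1 to compound 3 (within the scatter) and no change at the digits printed from compound 2 to compound 3 (within the scatter). None of them moves the read-out, whether the group is a saturated chain, a cyanobenzyl or a fused bicyclic aryl.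

Compound 4 `COc1ccc(-c2ccc3c(NCCCNCc4cccc(OC)c4O)ccnc3c2)cc1` continues this pattern of exchange at the same position: 4-methoxyphenyl in place of naphthalen-1-yl on an aromatic carbon. The change is of the same kind as the three steps already seen, which bear directly on it, and all of them were flat. The expectation is therefore no step beyond the scatter, no change at the digits printed from compound 3 to compound 4 (within the scatter), with the dissociating proton far removed from the altered group.

For compound 4 the estimate in this assay is 9.47, expected to fall between 9.2 and 9.75.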

Compound 4, acid dissociation constant: 9.47
Estimate against measurement, compound 4: no gap at the digits printed; measured number inside the range.
By their numbers in this assay, from the lowest: compounds 1, 2, 3 and 4 (each within the scatter of the next).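

In this assay the exchange of naphthalen-1-yl for 4-methoxyphenyl gives no change at the digits printed from compound 3 to compound 4 (within the scatter) and thus extends the flat picture at this aromatic carbon to a different kind of group: one six-membered aromatic ring of carbon only, with 1 hydrogen-bond acceptor and an oxygen atom, stands where 2 such rings stood, and the entering group carries fewer heavy atoms. The comparisons with the other two groups read the same way, with no change at the digits printed from compound 2 to compound 4 (within the scatter) for the exchange of 4-cyanobenzyl and no change at the digits printed from compound 1 to compound 4 (within the scatter) for the exchange of isopentyl, so all four compounds shown stand level at this position, and no compound among them goes against that. No supporting measurement is available to explain why these groups leave the values level.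

A carboxylic acid or a primary amine on this same aromatic carbon remains an open case, since every group shown here lacks such a function. Also open, from the compounds shown here alone, is a longer chain between the two nitrogens of the shared core, a change away from this position that these four compounds do not address.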